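The source may report more compounds than this note shows. Statements on the series, on what has been measured and on what is new or still open speak of the compounds shown alone.

Working notes on the series.

Two members of this series carry a growth read-out so far. In a functional assay on A2780 cells (Homo sapiens) for antiproliferative activity (on this read-out lower numbers stand for stronger inhibition of growth and higher numbers for weaker inhibition of growth), compound 1 `CC(C)C[C@H]1C[C@@H](Cl)C[C@@H](C2CCCCC2)O1` gives 20000 nM. Compound 2 `CC(C)C[C@H]1C[C@@H](Cl)C[C@@H](c2ccccc2)O1` gives 17000 nM in this assay. Compound 2 stands at the lowest of the two numbers, but its nearest neighbour, compound 1, lies within the scatter of it, so the pair shows no separation worth reading as order: both sit in the same weak range.

The next step keeps the core of compound 2 and changes one place: nitro in place of hydrogen on an aromatic carbon. The result is compound 3 `CC(C)C[C@H]1C[C@@H](Cl)C[C@@H](c2ccc([N+](=O)[O-])cc2)O1`, not yet measured in this assay. For the measured compounds named here, no step between measured compounds touches this part of the molecule, so there is no direct precedent for what a nitro on the aromatic ring does. Given that both measured members lie close together and weak, the step expected for compound 3 is a 1.4-fold lower number from compound 2 to compound 3 (0.15 log units; within the scatter), a small movement that does not clearly leave the scatter. Compound 3 is therefore estimated at 12000 nM in this assay, with a range from 4000 nM to 40000 nM.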

Compound 3, concentration for 50% growth inhibition: 21000 nM
The estimate for compound 3 lay 1.8-fold (0.24 log units) below the measured number; low and high end bracket the measured number.
By their numbers in this assay, from the lowest: compounds 2, 1 and 3 (each within the scatter of the next).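

In this assay, nitro in place of hydrogen on an aromatic carbon, para to a large group, gives a 1.2-fold higher number from compound 2 to compound 3 (0.09 log units; within the scatter), a step within the scatter. Compound 3 is the only member shown with a substituent on the aromatic ring, and it offers the first direct reading at this position: three added heavy atoms here leave the growth read-out indistinguishable from that of compound 2, in the same weak range. Nothing at hand bears on why this replacement produces no separation.

Going by these compounds, a single group at a single place does not define the position, so it remains open whether an amine, a carboxylic acid or a methoxy group on the same aromatic carbon would give a step beyond the scatter. Also open, on these data alone, are whether nitro on another carbon of the aromatic ring would behave as it does here, and whether replacing the chlorine or the chain on the shared core would lift the series out of this weak range.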